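The compounds below may be only part of what the source reports. "The series", "measured", "known", "first", "only" and "open" are said of these compounds alone.

Measured in an ADME assay on Raji cells (Homo sapiens) for cytotoxicity, read by luminescence, with a stated time of 72 h (a higher number here means that more compound is needed for the effect, a lower number that less compound is needed), each entry a limit and not a number:

- compound 1 `CCOC(=O)c1c(-c2cccc(Br)c2)[nH]c2cc(OC)ccc2c1=O`: > 21500 nM
- compound 2 `CCOC(=O)c1c(-c2cccc(OC)c2)[nH]c2cc(C(F)(F)F)ccc2c1=O`: > 21500 nM
- compound 3 `CCOC(=O)c1c(-c2cccc(OC)c2)[nH]c2cc(F)cc(F)c2c1=O`: > 21500 nM

Compound 3 therefore has no exact value, only its limit of > 21500 nM. It shares this position with the other two compounds, as the limit of > 21500 nM in this assay, at which 3 of the 3 values shown sit, shows.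

Compound 4 `CCOC(=O)c1c(-c2cccc(Oc3ccccc3)c2)[nH]c2cc(F)cc(F)c2c1=O` replaces methoxy with phenoxy, putting phenyl in place of methyl on an oxygen on an aromatic ring. Going by the values given here, no measured pair shows the effect of such a change, so in this assay no step beyond the scatter is expected, in either direction. The estimate for this is an at least 1.0-fold lower number from compound 3 to compound 4 (0.03 log units; that floor lies within the scatter). For compound 4 the estimated value is 20000 nM, within an expected range of 6000 nM to 40000 nM.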

Compound 4, half-maximal effective concentration: > 21500 nM
Compound 4 was reported as a limit; the forecaster's own chance of this, stated with the estimate: 75%; middle value at least 1.0-fold (0.03 log units) away from the limit.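

Going by these compounds alone, compound 3 and compound 4 are both reported only as limits, so no step between them can be read: the limit of > 21500 nM in this assay, at which 4 of the 4 values shown sit. The compounds shown leave open whether phenoxy in place of methoxy changes the number in this assay at all.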